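The compounds below may be only part of what the source reports. "The series", "measured", "known", "first", "only" and "open" are said of these compounds alone.

In a functional assay on cells (leukaemia cell line, Homo sapiens) for inhibition, read by sulforhodamine B assay, with a stated time of 48 h (on this read-out higher numbers stand for weaker inhibition of growth and lower numbers for stronger inhibition of growth), compound 1 (`O=S(=O)(Nc1ccc(Cl)c(Cl)c1)c1ccc(-c2cnc(C3CC3)o2)cc1`) gives 62100 nM, compound 2 (`O=S(=O)(Nc1ccc(Cl)c(F)c1)c1ccc(-c2cnc(C3CC3)o2)cc1`) gives 63000 nM and compound 3 (`O=S(=O)(Nc1ccc(Br)c(Cl)c1)c1ccc(-c2cnc(C3CC3)o2)cc1`) gives 70300 nM. Compound 3 therefore stands level with the other two, within the scatter of both. Compound 4 (`Cc1ccc(NS(=O)(=O)c2ccc(-c3cnc(C4CC4)o3)cc2)cc1C`) differs from it by one change, 3,4-dimethylphenyl in place of 4-bromo-3-chlorophenyl on a sulfonamide nitrogen. The relevant measured steps only exchange halogens: a 1.0-fold higher number from compound 1 to compound 2 (0.01 log units; within the scatter), a 1.1-fold higher number from compound 1 to compound 3 (0.05 log units; within the scatter) and a 1.1-fold higher number from compound 2 to compound 3 (0.05 log units; within the scatter). All three lie within the scatter. Among the compounds with values here, no measured step replaces the halogens with methyl groups, so this evidence is indirect. No step beyond the scatter is expected in this assay. The expected change is a 1.1-fold lower number from compound 3 to compound 4 (0.03 log units; within the scatter). The estimated value for compound 4 is 66000 nM, with an expected range of 42000 nM to 100000 nM.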

Compound 4, concentration for total growth inhibition: > 100000 nM
Compound 4: a limit, no number (the forecaster's own chance of this, stated with the estimate: 15%); middle value at least 1.5-fold (0.18 log units) from the limit.
By their numbers in this assay, from the lowest: compounds 1, 2 and 3 (each within the scatter of the next). At a limit, above all of these: compound 4.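

In this assay compound 4 gives no number, only a limit: the limit of > 100000 nM in this assay, at which 1 of the 4 values shown sits. At this position on the sulfonamide nitrogen, 3,4-dimethylphenyl gives an at least 1.4-fold higher number from compound 3 to compound 4 (0.15 log units; that floor lies within the scatter), an at least 1.5-fold higher number from compound 2 to compound 4 (0.20 log units; that floor lies within the scatter) and an at least 1.6-fold higher number from compound 1 to compound 4 (0.20 log units; that floor lies within the scatter). Within the data shown here, this is the first change here to reach the limit, where the halogen exchanges stayed level, yet each floor alone does not separate 3,4-dimethylphenyl from the halogenated phenyl groups. As far as these compounds go, how far compound 4 truly lies from the others remains open, as does what a single methyl group, a methoxy group or an amine in place of the halogens would give.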